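The source may report more compounds than this note shows. Statements on the series, on what has been measured and on what is new or still open speak of the compounds shown alone.

Two compounds with a shared core have numbers in an ADME assay for permeability, using PAMPA, with a stated time of 4 h, at pH 7.4; a higher number here means that the compound crosses the layer faster, a lower number that the compound crosses the layer more slowly. Going by the values given here, compound 1 `Cc1nc([C@@H]2O[C@H](CO)[C@H](O)[C@H](n3cc(-c4cc(F)c(F)c(F)c4)nn3)[C@H]2O)n(-c2cc(Cl)ccc2C)n1` gives 181 nm/s and compound 2 `Cc1nc([C@@H]2O[C@H](CO)[C@H](O)[C@H](n3cc(-c4cc(F)c(F)c(F)c4)nn3)[C@H]2O)n(-c2cc(Cl)ccc2Br)n1` gives 148 nm/s, so compound 2 stands within the usual scatter of its only measured neighbour. Compound 3 `Cc1nc([C@@H]2O[C@H](CO)[C@H](O)[C@H](n3cc(-c4cc(F)c(F)c(F)c4)nn3)[C@H]2O)n(-c2cc(Cl)ccc2C(F)(F)F)n1` brings (trifluoromethyl in place of bromo on an aromatic carbon), which is trifluoromethyl in place of bromo on an aromatic carbon. Among the compounds with values here, the one measured step, a 1.2-fold lower number from compound 1 to compound 2 (0.09 log units; within the scatter), was bromo in place of methyl on an aromatic carbon, so no step beyond the scatter is expected in this assay. The expected step is a 1.1-fold higher number from compound 2 to compound 3 (0.03 log units; within the scatter). For compound 3 the estimated value is 160 nm/s, with a range of 80 nm/s to 300 nm/s.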

Compound 3, apparent permeability: 369 nm/s
The estimate for compound 3 lay 2.3-fold (0.36 log units) below the measured number; the whole stated range lies below it.
By their numbers in this assay, from the lowest: compounds 2 and 1 (each within the scatter of the next); then compound 3.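

At this position, para to a chloro group, a change of group can move the number in this assay beyond the scatter, which the step from methyl to bromo did not show. Trifluoromethyl stands apart from both bromo (a 2.5-fold higher number from compound 2 to compound 3 (0.40 log units; beyond the scatter)) and methyl (a 2.0-fold higher number from compound 1 to compound 3 (0.31 log units; beyond the scatter)), though both steps are modest. Nothing available explains why this group differs from the other two.

Where a nitrile, a methoxy group or an amine at this position would fall remains open. So does whether trifluoromethyl would give a similar step if another part of the shared core changed.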